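Fluorine on the allylic amine chain: compound 3 to compound 4

The source may hold more compounds than are shown below. What is called first, only, known or untested is meant among the compounds shown, and "the series" means these compounds.

Compound 3 `C/C(=C/CN)CN(C[C@H]1Cc2ccccc2CN1)[C@H]1CCCc2cccnc21` is the reference point here. In a functional assay on CCRF-CEM cells for antagonist activity at C-X-C chemokine receptor type 4 (Homo sapiens), read by calcium flux, with stated times of 25 min and 90 s (on this read-out lower numbers stand for stronger inhibition and higher numbers for weaker inhibition), compound 3 gives 28 nM, the lowest number among the three measured. Compound 1 `C/C(CN)=C(/F)CN(C[C@H]1Cc2ccccc2CN1)[C@H]1CCCc2cccnc21` gives 44 nM, and the step of a 1.6-fold lower number from compound 1 to compound 3 (0.20 log units; within the scatter) stays within the scatter, so these two cannot be ranked against each other. Compound 2 `FC1(F)CCC(NC/C=C\CN(C[C@H]2Cc3ccccc3CN2)[C@H]2CCCc3cccnc32)CC1` gives 98 nM, a number clearly apart from that of compound 3.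

Compound 4 `C/C(CN)=C(\F)CN(C[C@H]1Cc2ccccc2CN1)[C@H]1CCCc2cccnc21` is not yet measured; it differs from compound 3 by a group of 6 heavy atoms (4 carbon, 1 nitrogen, 1 fluorine; no ring) in place of a group of 5 heavy atoms (4 carbon, 1 nitrogen; no ring), on a saturated chain carbon bound to an amine nitrogen. Going by the values given here, the only step bearing on this change is a 1.6-fold lower number from compound 1 to compound 3 (0.20 log units; within the scatter), which removed the same fluorine and remained within the scatter. The expected step of a 1.6-fold higher number from compound 3 to compound 4 (0.21 log units; within the scatter) is therefore small, with no direction beyond the scatter. For compound 4 the estimate is 45 nM, expected to fall between 20 nM and 110 nM.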

Compound 4, half-maximal inhibitory concentration: 28 nM
Beside the measured number, compound 4's estimate is 1.6-fold (0.21 log units) above it; measured number inside the range.
By their numbers in this assay, from the lowest: compounds 3, 4 and 1 (each within the scatter of the next); then compound 2.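

In this assay, placing 2-(aminomethyl)-1-fluoroprop-1-en-1-yl on a saturated chain carbon bound to an amine nitrogen gives no change at the digits printed from compound 3 to compound 4 (within the scatter), so this fluorine-bearing group is tolerated at this place in the drawn E form. The double-bond geometry has no readable effect here, with a 1.6-fold lower number from compound 1 to compound 4 (0.20 log units; within the scatter), and this reading of the pair rests on one point: the fact that compounds 1 and 4 differ only in the configuration as drawn

The compounds shown leave open whether chlorine or a methoxy group in place of this fluorine would hold the number in this range. From the compounds shown here alone, a longer chain carrying the amine also remains open.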